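Butyl replacing phenyl on a methyl-bearing core

The source may report more compounds than this note shows. Statements on the series, on what has been measured and on what is new or still open speak of the compounds shown alone.

In a functional assay on K562 cells (Homo sapiens) for inhibition, read by fluorescence, with a stated time of 72 h (on this read-out lower numbers stand for stronger inhibition of growth and higher numbers for weaker inhibition of growth), compound 2 `Cc1nc(-c2ccccc2)cc2nn(-c3ccccc3)cc12` gives 6300 nM. Compound 1 `CCCCc1cc2nn(-c3ccccc3)cc2cn1` gives 6700 nM in this assay, and the two numbers lie within the scatter of each other. Compound 3 `CCCCc1cc2nn(-c3ccccc3)cc2c(C)n1` differs from compound 2 by butyl in place of phenyl on an aromatic carbon. Compound 1 already carries the butyl group without the methyl group, and its number sits close to that of compound 2, so no step beyond the scatter is expected from compound 2 to compound 3, in either direction. Compound 3 is therefore expected to give about 6500 nM in this assay, with a range from 3000 nM to 14000 nM, the estimate corresponding to a step of a 1.0-fold higher number from compound 2 to compound 3 (0.01 log units; within the scatter).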

Compound 3, concentration for 50% growth inhibition: 8500 nM
Compound 3: middle estimate off by 1.3-fold (0.12 log units), on the low side; the measured number falls inside the stated range.
By their numbers in this assay, from the lowest: compounds 2, 1 and 3 (each within the scatter of the next).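

In this assay, butyl in place of phenyl on this aromatic carbon gives a 1.3-fold higher number from compound 2 to compound 3 (0.13 log units; within the scatter) with the methyl group present, so the two groups are not told apart here. Methyl in place of hydrogen on an aromatic carbon gives a 1.3-fold higher number from compound 1 to compound 3 (0.10 log units; within the scatter) with butyl held fixed, so this second position shows no separation either. No measurement offers an explanation for these close numbers. Going by these compounds, whether an amine, a carboxylic acid or a longer chain on this aromatic carbon would give a step beyond the scatter remains open.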